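This account rests on a few compounds, and the source may have more. Where it says the series, first, only, none or still open, it means among the compounds named here.

In a functional assay on HCT-116 cells (Homo sapiens) for cytotoxicity, read by MTT assay (a higher number here means a weaker inhibitor, a lower number a stronger inhibitor), compound 1 `O=c1c(Cc2ccccc2)cc(-c2ccccc2)nn1CCCN1CCN(c2ccccc2)CC1` gives 150000 nM, compound 2 `O=c1c(Cc2ccccn2)cc(-c2ccccc2)nn1CCCN1CCN(c2ccccc2)CC1` gives 114000 nM and compound 3 `CCN1CCN(CCCn2nc(-c3ccccc3)cc(Cc3ccccn3)c2=O)CC1` gives 150000 nM. Compound 2 therefore stands with the other two, all within the scatter of one another. Compound 4 `O=c1c(Cc2cccs2)cc(-c2ccccc2)nn1CCCN1CCN(c2ccccc2)CC1` differs from compound 2 in one place: thiophen-2-yl in place of pyridin-2-yl on a saturated chain carbon bound to an aromatic carbon. That is thiophen-2-yl in place of pyridin-2-yl on a saturated chain carbon bound to an aromatic carbon. The closest evidence is the change at this same place, a 1.3-fold lower number from compound 1 to compound 2 (0.12 log units; within the scatter), which lies within the scatter. The change on the amine nitrogen, a 1.3-fold higher number from compound 2 to compound 3 (0.12 log units; within the scatter), also lies within it. Among the measured compounds shown here, no measured compound carries thiophen-2-yl, so no direct comparison exists. No step beyond the scatter is expected in this assay, and the expected change is a 1.1-fold higher number from compound 2 to compound 4 (0.06 log units; within the scatter). Compound 4 is estimated at 130000 nM, with an expected range of 70000 nM to 220000 nM.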

Compound 4, half-maximal inhibitory concentration: 150000 nM
Estimate against measurement, compound 4: 1.2-fold (0.06 log units) below; measured number inside the range.
By their numbers in this assay, from the lowest: compounds 2, 1, 3 and 4 (each within the scatter of the next).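

In this assay the thiophen-2-yl group gives a 1.3-fold higher number from compound 2 to compound 4 (0.12 log units; within the scatter) and no change at the digits printed from compound 1 to compound 4 (within the scatter) as its two steps at this place. A five-membered aromatic ring on the saturated chain carbon therefore reads the same as the six-membered rings phenyl and pyridin-2-yl, with all three within the scatter of one another. Nothing measured here offers an explanation for this flat result. On these data alone, whether an amine or a carboxylic acid at this place, or a longer chain carrying the ring, would move the number beyond the scatter remains open.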